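The source may hold more compounds than are shown below. What is called first, only, known or untested is meant among the compounds shown, and "the series" means these compounds.

In a functional assay with Rattus norvegicus as the target (a lower number here means that less compound is needed, a higher number that more compound is needed for the effect), compound 1 (`CCCCCCCCC(=O)NCc1cccc(OC)c1`) gives > 100000 nM as a limit of the assay, not a number. Compound 2 (`CCCCCCCCC(=O)NCc1ccc(S)c(OC)c1`) gives > 100000 nM as a limit as well, so its place on the scale is known only as that limit. The record so far is thus the limit of > 100000 nM in this assay, at which 2 of the 2 values shown sit, and holds no numerical value.

Compound 3 (`CCCCCCCCC(=O)NCc1ccc([N+](=O)[O-])c(OC)c1`) has nitro in place of sulfanyl on an aromatic carbon, ortho to a methoxy group and para to a large group (nitro in place of sulfanyl on an aromatic carbon). Going by the values given here, the only measured step that bears on this change is a step that the two limits leave unreadable from compound 1 to compound 2 and it offers no size to carry over. Among the compounds with values here, it does show that sulfanyl in place of hydrogen at this carbon gave no readable value, and no measured compound yet carries nitro. No readable shift in either direction is therefore expected in this assay for this exchange, and another limit is the likeliest report. The estimated change is a number no higher from compound 2 to compound 3 (the limit leaves the size open) and rests on very little. For compound 3 the expected value is 100000 nM with an estimated range from 30000 nM to 300000 nM as its span.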

Compound 3, half-maximal effective concentration: 7910 nM
For compound 3 the middle estimate is 13-fold (1.10 log units) above the measured one, and the stated range ends above it.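

Putting nitro in place of sulfanyl on this aromatic carbon, ortho to a methoxy group and para to a large group, gives in this assay an at least 12-fold lower number from compound 2 to compound 3 (1.10 log units; beyond the scatter). Nitro in place of hydrogen on the same carbon gives an at least 12-fold lower number from compound 1 to compound 3 (1.10 log units; beyond the scatter), so what stands at this position can move the result beyond the scatter, and both sizes are bounds, since each step starts from a limit. Compound 3 therefore holds the only readable value among the three compounds, while compound 1 and compound 2 remain at the limit: the limit of > 100000 nM in this assay, at which 2 of the 3 values shown sit.

The step between compound 1 and compound 2 cannot be read, so hydrogen and sulfanyl at this carbon stay unordered, and a single nitro compound cannot tell which feature of the nitro group matters. Going by these compounds, it remains open whether a nitrile, a trifluoromethyl group or an amine on this carbon would also give a readable value, and whether the nitro gain would persist with a longer chain on the amide carbonyl or without the methoxy group.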